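Dichlorophenyl for chlorophenyl on two cores: working notes

The source may hold more compounds than are shown below. What is called first, only, known or untested is meant among the compounds shown, and "the series" means these compounds.

Measured compounds in an assay on isolated protein for inhibition of Polyunsaturated fatty acid 5-lipoxygenase (Homo sapiens), read by HPLC, with a stated time of 10 min; on this read-out higher numbers stand for weaker inhibition and lower numbers for stronger inhibition:
compound 1 `Cc1cc(OCc2nc3ccccc3s2)ccc1NC(=O)Nc1ccc(Cl)cc1` gives 570 nM.
compound 2 `Cc1cc(OCc2nc3ccccc3s2)ccc1NC(=O)Nc1cc(Cl)cc(Cl)c1` gives 80 nM.
compound 3 `Cc1cc(NC(=O)Nc2ccc(Cl)cc2)ccc1OCc1nc2ccccc2s1` gives only the assay limit, > 10000 nM.

Compound 1 and compound 3 have the same atoms joined differently; the difference between the two cores is not broken down here. On the core of compound 1 the change 3,5-dichlorophenyl in place of 4-chlorophenyl on an amide-type nitrogen is measured: a 7.1-fold lower number from compound 1 to compound 2 (0.85 log units; beyond the scatter).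

Compound 4 `Cc1cc(NC(=O)Nc2cc(Cl)cc(Cl)c2)ccc1OCc1nc2ccccc2s1` is the not yet measured partner of compound 3 and carries the same change, (3,5-dichlorophenyl in place of 4-chlorophenyl on an amide-type nitrogen), on the core of compound 3. The place is the same in words for both pairs, so the change is the same.

What is expected for compound 4 rests on two things: on the measured step in this assay from compound 1 to compound 2, a 7.1-fold lower number from compound 1 to compound 2 (0.85 log units; beyond the scatter), and on the fact that compound 3 sits at the limit described by the limit of > 10000 nM in this assay, at which 1 of the 3 values shown sits, so its true value is not a number and the starting point of the step is not known. If the step on the core of compound 3 were of the size seen on the core of compound 1, compound 4 is expected to land at 5000 nM in this assay, within 1500 nM to 10000 nM, that is, a step of an at least 2.0-fold lower number from compound 3 to compound 4 (0.30 log units; that floor lies within the scatter) counted from the limit. A result that is again only a limit is considered fairly likely.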

Compound 4, half-maximal inhibitory concentration: 720 nM
Estimate against measurement, compound 4: 6.9-fold (0.84 log units) above; the measured number lies below the stated range.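

In this assay, 3,5-dichlorophenyl in place of 4-chlorophenyl on an amide-type nitrogen also gives a lower number on the core of compound 3, where the step is an at least 13-fold lower number from compound 3 to compound 4 (1.14 log units; beyond the scatter). Compound 3 stands at > 10000 nM, which is a limit of the assay and not a number. The direction of the change therefore carries from one core to the other in these two pairs, but a shared size is not shown: the same change on two cores in this assay, a 7.1-fold lower number (0.85 log units; beyond the scatter) from compound 1 to compound 2 and an at least 13-fold lower number (1.14 log units; beyond the scatter) from compound 3 to compound 4; the limit leaves it open whether they differ

The compounds shown leave open whether the same direction would hold for other groups on that nitrogen, such as 3-chlorophenyl or 3,5-dimethylphenyl, on either core. They also leave open whether a true value for the 4-chlorophenyl member of the core of compound 3, in place of the limit, would set the two steps apart or bring them together.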